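Ester side-chain variation on a shared glycoside core

The source may hold more compounds than are shown below. What is called first, only, known or untested is meant among the compounds shown, and "the series" means these compounds.

Compound 1 `C/C=C1/[C@H](O[C@@H]2O[C@H](CO)[C@@H](O)[C@H](O)[C@H]2O)OC=C(C(=O)OC)[C@H]1CC(=O)OCC` is the parent of this set. In a functional assay on SK-BR-3 cells (Homo sapiens) for antiproliferative activity, read by MTT assay, with a stated time of 72 h (on this read-out higher numbers stand for weaker inhibition and lower numbers for stronger inhibition), compound 1 gives > 15000 nM, which is a limit of the assay rather than a number. Compound 2 `C/C=C1/[C@H](O[C@@H]2O[C@H](COC(C)=O)[C@@H](OC(C)=O)[C@H](OC(C)=O)[C@H]2OC(C)=O)OC=C(C(=O)OC)[C@H]1CC(=O)OC` carries the acetylated sugar with a methyl ester. In this assay compound 2 gives > 15000 nM, again a limit. Compound 3 `C/C=C1/[C@H](O[C@@H]2O[C@H](COC(C)=O)[C@@H](OC(C)=O)[C@H](OC(C)=O)[C@H]2OC(C)=O)OC=C(C(=O)OC)[C@H]1CC(=O)OCCC(C)C` extends that ester to isobutyl. In this assay compound 3 gives > 15000 nM, also a limit. The step that the two limits leave unreadable from compound 2 to compound 3 therefore cannot be read. For the measured compounds named here, all values sit at the same limit (the limit of > 15000 nM in this assay, at which 3 of the 3 values shown sit), so no measured step yields a readable size or direction.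

Compound 4 `C/C=C1/[C@H](O[C@@H]2O[C@H](CO)[C@@H](O)[C@H](O)[C@H]2O)OC=C(C(=O)OC)[C@H]1CC(=O)OCc1ccc2c(c1)OCCO2` differs from compound 1 by 2,3-dihydro-1,4-benzodioxin-6-yl in place of methyl on a saturated chain carbon bound to an oxygen next to a carbonyl group. Going by the values given here, no measured step mirrors this change, and the step from compound 2 to compound 3 at the same place was unreadable. The expected step that the limit leaves unreadable from compound 1 to compound 4 is none beyond the scatter, with the expectation resting on the limits. Compound 4 is estimated at 20000 nM in this assay, with a range from 7000 nM to 60000 nM, and it is expected most likely to return only a limit as well.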

Compound 4, half-maximal inhibitory concentration: > 15000 nM
Compound 4: no number, only a limit (the forecaster's own chance of this, stated with the estimate: 75%); the middle value is on the limit's open side.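

In this assay compound 4 gives > 15000 nM, a limit and not a number, so the step between compound 1 and compound 4 cannot be read. The compounds shown leave open whether any ester side chain on the shared core gives a readable value: the limit of > 15000 nM in this assay, at which 4 of the 4 values shown sit.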